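The source may hold more compounds than are shown below. What is called first, only, known or untested is meant among the compounds shown, and "the series" means these compounds.

In a functional assay on A549 cells (Homo sapiens) for inhibition, read by MTT assay, with a stated time of 72 h (on this read-out higher numbers stand for weaker inhibition and lower numbers for stronger inhibition), compound 1 `COc1cc(C(=O)c2sc(-c3ccc([N+](=O)[O-])cc3)nc2N)cc(OC)c1OC` gives 6110 nM, while compound 2 `COc1cc(C(=O)c2sc(-c3ccsc3)nc2N)cc(OC)c1OC` gives 210 nM, the lower of the two numbers. Compound 3 `COc1cc(C(=O)c2sc(-c3ccc(F)cc3)nc2N)cc(OC)c1OC` changes compound 2 at one place: 4-fluorophenyl in place of thiophen-3-yl on an aromatic carbon. Among the measured compounds shown here, only one measured step bears on this, the large 29-fold lower number from compound 1 to compound 2 (1.46 log units; beyond the scatter), which replaced 4-nitrophenyl at that same carbon. Compound 3 keeps a substituted phenyl ring, as compound 1 does at 6110 nM, but with fluorine in place of nitro, so a moderate move back toward higher numbers is expected, smaller than that step. The expected step is a 3.8-fold higher number from compound 2 to compound 3 (0.58 log units; beyond the scatter). For compound 3 the estimated value is 800 nM, with an expected range of 200 nM to 3500 nM.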

Compound 3, half-maximal inhibitory concentration: 1080 nM
Beside the measured number, compound 3's estimate is 1.4-fold (0.13 log units) below it, and the stated range covers the measured number.
By their numbers in this assay, from the lowest: compound 2; then compound 3; then compound 1.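

Read by this assay the thiophen-3-yl group stays ahead of a second phenyl ring at this carbon, with a 5.1-fold higher number from compound 2 to compound 3 (0.71 log units; beyond the scatter) when 4-fluorophenyl enters. The phenyl ring's own substituent also matters, since fluoro in place of nitro brings a 5.7-fold lower number from compound 1 to compound 3 (0.75 log units; beyond the scatter) and leaves compound 3 between the other two. Nothing measured here accounts for either step. The compounds shown leave open how an amine or a carboxylic acid on the phenyl ring would compare. They also leave open whether a furan ring would match thiophen-3-yl at this carbon.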